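Swapping the Ethylphenyl Arm of a Pyrimidine Urea

The source may hold more compounds than are shown below. What is called first, only, known or untested is meant among the compounds shown, and "the series" means these compounds.

Compound 1 `CCc1ccc(Nc2cc(NC(=O)Nc3cc(OC)cc(OC)c3)ncn2)cc1`: 78%
Compound 2 `COc1ccc(C(F)(F)F)cc1Nc1cc(NC(=O)Nc2c(Cl)cccc2Cl)ncn1`: 89%

Of the compounds shown here, two have been measured so far in a functional assay on PC-9 cells (Homo sapiens) for inhibition, read by MTT assay, with a stated time of 48 h, tested at 10 uM; a higher number here means more inhibition at the concentration tested (going by the name of the read-out), a lower number less inhibition. Compound 1 gives 78%, the lowest of the two numbers. Compound 2 gives 89%, a number higher by more than the usual scatter. The two structures differ in several places at once, so no single step can be read out of this pair; it only shows that both compounds give a high inhibition number at the concentration tested.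

Compound 3 `COc1cc(NC(=O)Nc2cc(Nc3ccc(OC)c(I)c3)ncn2)cc(OC)c1` has not yet been measured. It is compound 1 with one change: 3-iodo-4-methoxyphenyl in place of 4-ethylphenyl on a nitrogen on an aromatic ring. Going by the values given here, no measured pair isolates this kind of change, so the expectation rests on compound 1 alone and on the observation that both measured compounds sit high. The step from compound 1 to compound 3 is expected to be a number 4 percentage points higher from compound 1 to compound 3 (within the scatter), a small rise that may well remain within the scatter. Compound 3 is therefore estimated at 82%, with a plausible range from 65% to 95%.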

Compound 3, a percentage reported as inhibition, at one concentration (the size of the read-out at that concentration, not a potency): 47.1%
Estimate against measurement, compound 3: 34.9 percentage points above; measured number below the stated range.
By their numbers in this assay, from the lowest: compound 3; then compound 1; then compound 2.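

In this assay, putting 3-iodo-4-methoxyphenyl in place of 4-ethylphenyl on a nitrogen on an aromatic ring gives a number 30.9 percentage points lower from compound 1 to compound 3 (beyond the scatter). Going by these compounds alone, this is the first comparison here that changes one place only, and it shows that the number depends strongly on the group at this position: the rest of compound 1, left unchanged, does not keep inhibition high by itself. No measurement shown here explains the fall.

The change removes the ethyl group and adds both a methoxy group and an iodine atom, so these compounds cannot show which part of the swap matters. As far as these compounds go, it remains open whether 4-methoxyphenyl, 3-iodophenyl, or a phenyl ring carrying an amine or a carboxylic acid would give a number closer to that of compound 1 or compound 3.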